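A few compounds are considered here, and "the series" means these few. Any claim that something is new, unique, unknown or untested is made for them only; others in the source may bear on it.

In a functional assay on HCT-116 cells (Homo sapiens) for antiproliferative activity, read by MTT assay, with a stated time of 72 h (on this read-out lower numbers stand for stronger inhibition and higher numbers for weaker inhibition), compound 3 (`COc1ncc(-c2ccc3c(c2)N(c2ccc(F)cc2)C(=O)CO3)cc1NS(=O)(=O)c1ccc(F)cc1`) stands only as a limit (> 40000 nM) and not as a number. In the same assay, compound 1 (`COc1ncc(-c2ccc3c(c2)N(c2ccc(C)cc2)C(=O)CO3)cc1NS(=O)(=O)c1ccc(F)cc1`) gives 22700 nM and compound 2 (`COc1ncc(-c2ccc3c(c2)NC(=O)CO3)cc1NS(=O)(=O)c1ccc(F)cc1`) gives 24900 nM on these cells.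

The change to compound 4 (`COc1ncc(-c2ccc3c(c2)N(C2CCCCC2)C(=O)CO3)cc1NS(=O)(=O)c1ccc(F)cc1`) is cyclohexyl in place of 4-fluorophenyl on an amide-type nitrogen in a ring. Within the data shown here, no measured compound carries cyclohexyl, so only indirect evidence is available. At the same nitrogen, hydrogen in place of 4-methylphenyl gives a 1.1-fold higher number from compound 1 to compound 2 (0.04 log units; within the scatter) and 4-fluorophenyl in place of hydrogen gives an at least 1.6-fold higher number from compound 2 to compound 3 (0.20 log units; that floor lies within the scatter) on this read-out. Elsewhere on that substituent, fluoro in place of methyl gives an at least 1.7-fold higher number from compound 1 to compound 3 (0.24 log units; that floor lies within the scatter) as the remaining step. None of these steps shows a change beyond the scatter, although two of them are only floors set by the limit of compound 3.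

In this assay a small shift towards lower numbers is expected, and no shift beyond the scatter is also possible. The expected step is an at least 1.3-fold lower number from compound 3 to compound 4 (0.12 log units; that floor lies within the scatter) on this estimate. For compound 4 the estimated value is 30000 nM with an expected range from 12000 nM to 50000 nM in this series.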

Compound 4, half-maximal inhibitory concentration: > 40000 nM
Compound 4: only a limit was reported; the forecaster's own chance of this, stated with the estimate: 40%; at least 1.3-fold (0.12 log units) between middle value and limit.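

With cyclohexyl, a non-aromatic ring of carbon only, on the amide-type nitrogen, compound 4 stands in this assay only as a limit, > 40000 nM, so this change to the ring type gives no measured value. Cyclohexyl in place of hydrogen gives an at least 1.6-fold higher number from compound 2 to compound 4 (0.20 log units; that floor lies within the scatter), and cyclohexyl in place of 4-methylphenyl gives an at least 1.7-fold higher number from compound 1 to compound 4 (0.24 log units; that floor lies within the scatter), so neither comparison shows a change beyond the scatter, and the position still has no substituent with a readable gain or loss. The step between compound 3 and compound 4 cannot be read because both stand at the same limit: the limit of > 40000 nM in this assay, at which 2 of the 4 values shown sit.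

From the compounds shown here alone, whether an aminoalkyl chain, a carboxylic acid or a longer alkyl chain on this nitrogen would give a clearly lower number than the values of compound 1 and compound 2 remains open. With two of the four compounds at a limit and every readable step a floor within the scatter, no ranking of the groups at this nitrogen can be drawn, and any difference between 4-fluorophenyl and cyclohexyl remains unresolved.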